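Sulfonyl aryl swap in the bipiperidine sulfonamide series

A few compounds are considered here, and "the series" means these few. Any claim that something is new, unique, unknown or untested is made for them only; others in the source may bear on it.

Measured so far:
- compound 1, `CC1CCN(C2CCN(S(=O)(=O)c3ccc(F)cc3F)CC2)CC1`: > 5000 nM
- compound 2, `Cc1cc(C)c(S(=O)(=O)N2CCC(N3CCC(CCO)CC3)CC2)c(C)c1`: > 5000 nM

In an ADME assay on HCT-116 cells (Homo sapiens) for cytotoxicity, read by CellTiter-Glo, with a stated time of 72 h (a lower number here means a stronger inhibitor, a higher number a weaker inhibitor), compound 1 gives > 5000 nM, which is a limit of the assay and not a number. In this assay compound 2 likewise gives > 5000 nM, again only a limit. For the measured compounds named here, the two values shown therefore carry no measurable number at all (the limit of > 5000 nM in this assay, at which 2 of the 2 values shown sit), and no step between measured compounds can be sized.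

Compound 3, `CC1CCN(C2CCN(S(=O)(=O)c3ccc(C#N)cc3)CC2)CC1`, has not yet been measured. It differs from compound 1 by 4-cyanophenyl in place of 2,4-difluorophenyl on a sulfonyl sulfur. Going by the values given here, with both values shown sitting at the limit, there is no measured step on which to base a direction; the step from compound 1 to compound 3 is expected to be a step that the limit leaves unreadable from compound 1 to compound 3, that is none beyond the scatter. For compound 3 in this assay the expected value is 8000 nM, with a range from 3000 nM to 30000 nM, most likely reported again as a limit.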

Compound 3, half-maximal inhibitory concentration: > 5000 nM
Compound 3 was reported as a limit; the forecaster's own chance of this, stated with the estimate: 85%; the middle value does not contradict the limit.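

For the compounds shown here, no step from compound 1 to compound 3 can be read in this assay, as both values are limits and not numbers: the limit of > 5000 nM in this assay, at which 3 of the 3 values shown sit.

Still open is whether 4-cyanophenyl in place of 2,4-difluorophenyl on a sulfonyl sulfur alters the value at all, and whether any compound shown gives a measurable number in this assay under these conditions.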